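Shortening the hydroxycarbamoyl chain of compound 2

The compounds below may be only part of what the source reports. "The series", "measured", "known", "first", "only" and "open" are said of these compounds alone.

Among the measured compounds shown here, in a functional assay on HT-29 cells (Homo sapiens) for antiproliferative activity, read by CCK-8 assay, with a stated time of 48 h (a higher number here means a weaker inhibitor, a lower number a stronger inhibitor), compound 2 (`O=C(CCCCCC(=O)NCCNc1nonc1/C(=N/O)Nc1ccc(F)c(Br)c1)NO`) gives 28700 nM, the only actual number so far. Compound 1 (`O=C(CCCCC(=O)NCCNc1nonc1/C(=N/O)Nc1ccc(F)c(Br)c1)NO`) reads > 100000 nM, which is a limit of the assay and not a number. Compound 3 (`O=C(CCCC(=O)NCCNc1nonc1/C(=N/O)Nc1ccc(F)c(Br)c1)NO`) has hydroxycarbamoyl in place of 2-(hydroxycarbamoyl)ethyl on a saturated chain carbon, three bonds along the chain from a carbonyl carbon. For the measured compounds named here, only one measured step bears on this change: lengthening the chain gave an at least 3.4-fold lower number from compound 1 to compound 2 (0.54 log units; beyond the scatter), a change beyond the scatter. Compound 3 moves the opposite way and ends up shorter than compound 1, so a higher number in this assay is expected, though one step is thin support. The expected change is a 4.2-fold higher number from compound 2 to compound 3 (0.62 log units; beyond the scatter). The estimate for compound 3 is 120000 nM, within an expected range of 45000 nM to 300000 nM, and only a limit may be reported.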

Compound 3, half-maximal inhibitory concentration: > 100000 nM
Compound 3 ended at the assay's limit (the forecaster's own chance of this, stated with the estimate: 70%); the middle value is on the limit's open side.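

In this assay, among the compounds shown here, hydroxycarbamoyl in place of 2-(hydroxycarbamoyl)ethyl on this saturated chain carbon gives an at least 3.4-fold higher number from compound 2 to compound 3 (0.54 log units; beyond the scatter) and confirms that shortening this chain from compound 2 weakens the result over a second chain length, not only the one seen before. The value of compound 3, > 100000 nM, is a limit of the assay and not a number. The step between compound 1 and compound 3 cannot be read, so the two shorter chains stay unordered, because both readings sit at the same limit: the limit of > 100000 nM in this assay, at which 2 of the 3 values shown sit.

Going by these compounds, whether a longer chain than that of compound 2 would give a still lower number remains open. Also open, on these data alone, is what a carboxylic acid in place of the hydroxycarbamoyl end would do at the chain length of compound 2.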